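The source may report more compounds than this note shows. Statements on the series, on what has been measured and on what is new or still open speak of the compounds shown alone.

Among the measured compounds shown here, in a functional assay on HepG2 cells (Homo sapiens) for cytotoxicity, read by MTT assay, with a stated time of 72 h (on this read-out lower numbers stand for stronger inhibition and higher numbers for weaker inhibition), two compounds have numbers so far. Compound 1, `CNC(=O)c1cc(Oc2ccc(C(=O)/C=C/c3ccc(Cl)c(Cl)c3)cc2)ccn1`, gives 11400 nM, and compound 2, `CNC(=O)c1cc(Oc2ccc(/C=C/C(=O)c3ccc(Br)cc3)cc2)ccn1`, gives 22000 nM. These two values lie within the scatter of each other, so compound 2 cannot be told apart from compound 1 on the numbers shown. Compound 3, `CNC(=O)c1cc(Oc2ccc(/C=C/C(=O)c3ccc([N+](=O)[O-])cc3)cc2)ccn1`, has nitro in place of bromo on an aromatic carbon, para to a large group: nitro in place of bromo on an aromatic carbon. For the measured compounds named here, no measured pair in this set shows what such a change does. With compound 2 at 22000 nM as the only direct reference, no step beyond the scatter is expected in this assay. The estimated 1.2-fold lower number from compound 2 to compound 3 (0.09 log units; within the scatter) is small and is not expected to carry a firm direction. For compound 3 the expected value is 18000 nM, within an estimated range from 7000 nM to 45000 nM.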

Compound 3, half-maximal inhibitory concentration: 41400 nM
Compound 3: middle estimate off by 2.3-fold (0.36 log units), on the low side; low and high end bracket the measured number.
By their numbers in this assay, from the lowest: compounds 1, 2 and 3 (each within the scatter of the next, the first and the last beyond it).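

In this assay, nitro in place of bromo on an aromatic carbon, para to a large group, gives a 1.9-fold higher number from compound 2 to compound 3 (0.27 log units; within the scatter). Among the compounds shown here, this is the first measured pair for this change, and it shows that 4-bromophenyl and 4-nitrophenyl cannot be told apart at this place, although the entering group is larger by heavy-atom count and carries hydrogen-bond acceptors that bromo lacks. For the compounds shown here, compound 1 differs from both compounds in more than one place, so it offers no second pair for this change.

The compounds shown leave open whether an amine, a carboxylic acid or a methoxy group at this place would give a number beyond the scatter of compound 2. They also leave open whether the same exchange would give a similar step on another core. No measurement at hand accounts for this result.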